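Replacing the 3-hydroxy-4-methoxyphenyl group of compound 3

This account rests on a few compounds, and the source may have more. Where it says the series, first, only, none or still open, it means among the compounds named here.

Compound 1 `Cc1ccc(S/C(=C/c2ccc(Br)cc2)C(=O)c2ccc(Cl)cc2)cc1` gives 25000 nM
Compound 2 `Cc1ccc(S/C(=C/c2sccc2C)C(=O)c2ccc(Cl)cc2)cc1` gives 50000 nM
Compound 3 `COc1ccc(/C=C(/Sc2ccc(C)cc2)C(=O)c2ccc(Cl)cc2)cc1O` gives 1000 nM

In a functional assay on DU-145 cells (Homo sapiens) for inhibition, read by trypan blue exclusion, with a stated time of 96 h (a lower number here means a stronger inhibitor of growth, a higher number a weaker inhibitor of growth), compound 3 stands lowest of the three, at 1000 nM. The unmeasured compound 4 `Cc1ccc(S/C(=C/c2ccc(Cl)cc2Cl)C(=O)c2ccc(Cl)cc2)cc1` differs from it at one place: 2,4-dichlorophenyl in place of 3-hydroxy-4-methoxyphenyl on a double-bonded chain carbon bound to a double-bonded chain carbon. Two measured steps at that place bear on this change, both large: a 25-fold lower number from compound 1 to compound 3 (1.40 log units; beyond the scatter) and a 50-fold lower number from compound 2 to compound 3 (1.70 log units; beyond the scatter). Between the other two groups, the step is a 2.0-fold higher number from compound 1 to compound 2 (0.30 log units; within the scatter). Compound 3 alone carries 3-hydroxy-4-methoxyphenyl, so a large rise back toward compound 1 and compound 2 is expected. The expected step is a 20-fold higher number from compound 3 to compound 4 (1.30 log units; beyond the scatter). For compound 4 the estimated value is 20000 nM, with an expected range from 5000 nM to 60000 nM.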

Compound 4, concentration for 50% growth inhibition: 10000 nM
Compound 4: the middle estimate sits 2.0-fold (0.30 log units) above what was measured; the measured number falls inside the stated range.
By their numbers in this assay, from the lowest: compound 3; then compound 4; then compounds 1 and 2 (each within the scatter of the next).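

In this assay the groups other than 3-hydroxy-4-methoxyphenyl no longer sit level, since 2,4-dichlorophenyl gives a 5.0-fold lower number from compound 2 to compound 4 (0.70 log units; beyond the scatter) and also a 2.5-fold lower number from compound 1 to compound 4 (0.40 log units; beyond the scatter) on the same double-bonded chain carbon. Compound 3 still keeps its lead, with a 10-fold higher number from compound 3 to compound 4 (1.00 log units; beyond the scatter), so a group with no hydrogen-bond donors or acceptors recovers only part of that gap. No measured evidence here explains this order. Which of the hydroxy and methoxy groups of compound 3 matters remains open. So does how an amine or a carboxylic acid on the phenyl ring would behave at this place.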